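The source may hold more compounds than are shown below. What is called first, only, known or untested is meant among the compounds shown, and "the series" means these compounds.

Compound 1 `C[C@@H]1O[C@H](C2CCCCC2)C([Si](C)(C)C)=C(Cl)[C@H]1C`, compound 2 `C[C@@H]1O[C@H](CCC=C(Br)Br)C([Si](C)(C)C)=C(Cl)[C@H]1C` and compound 3 `C#CCC[C@H]1O[C@@H](C)[C@H](C)C(Cl)=C1[Si](C)(C)C` share one core and differ only in the group on a saturated ring carbon. In a functional assay on A2780 cells (Homo sapiens) for antiproliferative activity (a lower number here means that less compound is tolerated, a higher number that more compound is tolerated), compound 1 gives 77000 nM, compound 2 gives 70000 nM and compound 3 gives 75000 nM. Compound 3 stands second highest of the three, and every step among them lies within the scatter: a 1.1-fold lower number from compound 1 to compound 2 (0.04 log units; within the scatter), a 1.0-fold lower number from compound 1 to compound 3 (0.01 log units; within the scatter) and a 1.1-fold higher number from compound 2 to compound 3 (0.03 log units; within the scatter). Compound 4 `C=CCC[C@H]1O[C@@H](C)[C@H](C)C(Cl)=C1[Si](C)(C)C` differs from compound 3 by vinyl in place of ethynyl on a saturated chain carbon, two bonds along the chain from a saturated ring carbon. The step from compound 2 to compound 3 altered the group at this same place and moved nothing beyond the scatter, so for compound 4 no shift beyond the scatter in this assay is expected: no change at the digits printed from compound 3 to compound 4 (within the scatter). Compound 4 is therefore estimated at 75000 nM, within 38000 nM to 150000 nM.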

Compound 4, concentration lethal to 50% of the cells: 19000 nM
For compound 4 the middle estimate is 3.9-fold (0.60 log units) above the measured one, and the stated range ends above it.
By their numbers in this assay, from the lowest: compound 4; then compounds 2, 3 and 1 (each within the scatter of the next).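

In this assay, this place on the chain is sensitive to the group it carries: vinyl gives the first separation beyond the scatter from ethynyl (a 3.9-fold lower number from compound 3 to compound 4 (0.60 log units; beyond the scatter)) and from 2,2-dibromoethenyl (a 3.7-fold lower number from compound 2 to compound 4 (0.57 log units; beyond the scatter)). On the saturated ring carbon, but-3-en-1-yl likewise parts from cyclohexyl (a 4.1-fold lower number from compound 1 to compound 4 (0.61 log units; beyond the scatter)). Nothing available explains this separation.

Going by these compounds, whether a saturated ethyl group at this place would track vinyl or ethynyl remains open. So does whether a longer chain ending in vinyl would keep the lower number.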